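This account rests on a few compounds, and the source may have more. Where it says the series, first, only, none or still open, it means among the compounds named here.

Working notes on the sulfonamide series. Compound 1 `CC1CCN(C2CCN(S(=O)(=O)c3cccnc3Cl)CC2)CC1` sits at the assay limit in a functional assay on DLD-1 cells (Homo sapiens) for antiproliferative activity, read by CellTiter-Glo, with a stated time of 72 h (a lower number here means a stronger inhibitor, a higher number a weaker inhibitor), giving > 5000 nM; that limit is the limit of > 5000 nM in this assay, at which 1 of the 3 values shown sits. Compound 2 `Cc1ccc(S(=O)(=O)N2CCC(N3CCC(C)CC3)CC2)cc1C` gives 24 nM, the highest of the two numbers shown, and compound 3 `COc1ccc(OC)c(S(=O)(=O)N2CCC(N3CCC(C)CC3)CC2)c1` gives 4.5 nM. Within the data shown here, the one measured step, an at least 200-fold lower number from compound 1 to compound 2 (2.31 log units; beyond the scatter), is the only guide to changes on the sulfonyl sulfur. Compound 4 `CC1CCN(C2CCN(S(=O)(=O)c3cccc(Cl)c3)CC2)CC1` differs from compound 2 by 3-chlorophenyl in place of 3,4-dimethylphenyl on a sulfonyl sulfur. Among the measured compounds shown here, no measured step covers an aryl-to-aryl swap of this kind, and the step from compound 1 to compound 2 bears only loosely on it. A modest step toward a higher number is expected, a 2.1-fold higher number from compound 2 to compound 4 (0.32 log units; beyond the scatter), so compound 4 is estimated at 50 nM, within 15 nM to 200 nM.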

Compound 4, half-maximal inhibitory concentration: > 5000 nM
Compound 4 was reported as a limit (the forecaster's own chance of this, stated with the estimate: 5%); middle value at least 100-fold (2.00 log units) away from the limit.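

Replacing 3,4-dimethylphenyl with 3-chlorophenyl on the sulfonyl sulfur gives an at least 200-fold higher number from compound 2 to compound 4 (2.31 log units; beyond the scatter). An aryl-to-aryl swap at this position can therefore cost as much activity as 2-chloropyridin-3-yl does, and a six-membered aromatic ring of carbon only does not protect against that loss. Compound 4 stands at a limit, as does compound 1, so the step between them cannot be read: the limit of > 5000 nM in this assay, at which 2 of the 4 values shown sit.

Still open, going by these compounds, is whether the loss follows the chlorine itself or the missing second ring substituent. A 3-methylphenyl or 3-methoxyphenyl group on the sulfonyl sulfur would separate these two readings.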